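Methoxy in Place of Tert-Butyl: An Expected Cytotoxicity

The source may report more compounds than this note shows. Statements on the series, on what has been measured and on what is new or still open speak of the compounds shown alone.

Measured so far:
Compound 1 `O=c1ccoc2cc(OCc3cn(Cc4ccc([N+](=O)[O-])cc4)nn3)ccc12` — 19300 nM
Compound 2 `CC(C)(C)c1ccc(Cn2cc(COc3ccc4c(=O)ccoc4c3)nn2)cc1` — 28800 nM

Both compounds share one core and differ only in the group on the outer aromatic ring. In a functional assay on SW480 cells (Homo sapiens) for cytotoxicity, read by MTT assay, with a stated time of 48 h (on this read-out higher numbers stand for weaker inhibition and lower numbers for stronger inhibition), compound 1 gives 19300 nM, and compound 2 gives 28800 nM. Among the compounds with values here, the one known step, a 1.5-fold higher number from compound 1 to compound 2 (0.17 log units; within the scatter), shows that exchanging the group at this place left the read-out essentially unchanged; compound 2 therefore stands together with compound 1 rather than apart from it.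

Compound 3 `COc1ccc(Cn2cc(COc3ccc4c(=O)ccoc4c3)nn2)cc1` is the next member: methoxy in place of tert-butyl on an aromatic carbon. This is the same kind of exchange at the same place as the step from compound 1 to compound 2, which stayed within the scatter. Compound 3 is therefore expected to show no step beyond the scatter, a 1.2-fold lower number from compound 2 to compound 3 (0.08 log units; within the scatter). The estimate for compound 3 in this assay is 24000 nM, with a range from 10000 nM to 55000 nM.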

Compound 3, half-maximal inhibitory concentration: 20400 nM
Compound 3: the middle estimate sits 1.2-fold (0.07 log units) above what was measured, within the range that was stated.
By their numbers in this assay, from the lowest: compounds 1, 3 and 2 (each within the scatter of the next).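

In this assay this place on the outer aromatic ring has now taken a third group with no clear effect on the read-out: methoxy in place of tert-butyl gives a 1.4-fold lower number from compound 2 to compound 3 (0.15 log units; within the scatter) and methoxy in place of nitro gives a 1.1-fold higher number from compound 1 to compound 3 (0.02 log units; within the scatter) as well. The earlier pair compared only nitro and tert-butyl, whereas these three groups, including methoxy with its hydrogen-bond acceptor and fewer heavy atoms than tert-butyl, all lie within the scatter of one another. No evidence is at hand that bears on the reason for this result.

On these data alone, it remains open whether an amine, a carboxylic acid or a longer chain at this place would move the number beyond the scatter. The compounds shown also share one core, so they say nothing about changes elsewhere in the structure.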